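Replacing methoxy with hydrogen on compound 1

The source may hold more compounds than are shown below. What is called first, only, known or untested is meant among the compounds shown, and "the series" means these compounds.

Measured so far in a functional assay, read by spectrophotometry, in phosphate buffer, with a stated time of 10 min, at pH 6.6; on this read-out lower numbers stand for an effect already at smaller amounts and higher numbers for an effect only at larger amounts of compound
- compound 1 (`COC(=O)C1=C(C)NC(=O)NC1c1ccc(OC)cc1`) gives 206 ug/mL
- compound 2 (`CCOC(=O)C1=C(C)NC(=O)NC1c1ccc([N+](=O)[O-])cc1`) gives 238 ug/mL

For the measured compounds named here, compound 1 stands level with compound 2, the only other measured compound, as their two values lie within the usual scatter of each other. Going by the values given here, no two measured compounds differ in one place only, so no measured step shows what a single change does here.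

The next compound is compound 3 (`COC(=O)C1=C(C)NC(=O)NC1c1ccccc1`), which has hydrogen in place of methoxy on an aromatic carbon, para to a large group. Among the compounds with values here, the only guide is that compound 1 (206 ug/mL) and compound 2 (238 ug/mL) do not separate beyond the scatter, and two values are thin support. No step beyond the scatter is therefore expected in either direction, although a larger step cannot be excluded. Expected is a 1.0-fold higher number from compound 1 to compound 3 (0.02 log units; within the scatter) and thus no change beyond the scatter. For compound 3 the estimated value is 215 ug/mL with an expected range from 105 ug/mL to 440 ug/mL in this measurement.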

Compound 3, half-maximal effective concentration: 97.6 ug/mL
Compound 3: middle estimate off by 2.2-fold (0.34 log units), on the high side, outside the stated range (below it).
By their numbers in this assay, from the lowest: compound 3; then compounds 1 and 2 (each within the scatter of the next).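

In this assay, for the compounds shown here, hydrogen in place of methoxy on an aromatic carbon, para to a large group, gives a 2.1-fold lower number from compound 1 to compound 3 (0.32 log units; beyond the scatter) and so provides the first single change that can be read. This position is thus not silent: with the rest of the molecule held constant, the compound carrying hydrogen there has the lower number and the one carrying methoxy the higher, which the earlier pair could not show, as compound 1 and compound 2 differ in more than one place. No measurement is available that would explain this modest step, so it stands as an observation only.

On these data alone, a single step cannot tell whether the higher number belongs to methoxy in particular or would follow other groups on this carbon, so it remains open whether a hydroxyl, an amine, a fluorine or a longer alkoxy chain there would stand with compound 1 or with compound 3. Also open, as far as these compounds go, is what the ester contributes on its own, for instance whether a carboxylic acid or an amide in its place would shift the value on the core of compound 3.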